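Compound 3 to compound 4: a nitrile shifts on the benzyl

The compounds below may be only part of what the source reports. "The series", "measured", "known", "first", "only" and "open" are said of these compounds alone.

Three compounds were measured in an ADME assay on MT4 cells (Homo sapiens) for cytotoxicity, read by MTT assay, with a stated time of 4 days; on this read-out lower numbers stand for higher toxicity in this test and higher numbers for lower toxicity in this test:

Compound 1, `O=C1c2sccc2NS(=O)(=O)N1Cc1ccccc1`, gives 374000 nM.
Compound 2, `O=C1c2sccc2N(Cc2ccccc2Cl)S(=O)(=O)N1Cc1ccccc1`, gives > 298000 nM, which is a limit of the assay and not a number.
Compound 3, `N#Cc1cccc(CN2c3ccsc3C(=O)N(Cc3ccccc3)S2(=O)=O)c1`, gives > 305000 nM, which is also a limit of the assay and not a number.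

Compound 3 thus stands at a limit in this assay, as described by the limit of > 305000 nM in this assay, at which 1 of the 3 values shown sits, and compound 2 stands at the limit described by the limit of > 298000 nM in this assay, at which 1 of the 3 values shown sits. Every measured step that touches compound 3 is unreadable for that reason: a step that the limit leaves unreadable from compound 1 to compound 3 and a step that the two limits leave unreadable from compound 2 to compound 3, and likewise a step that the limit leaves unreadable from compound 1 to compound 2.

Compound 4, `N#Cc1ccc(CN2c3ccsc3C(=O)N(Cc3ccccc3)S2(=O)=O)cc1`, differs from compound 3 by 4-cyanophenyl in place of 3-cyanophenyl on a saturated chain carbon bound to a sulfonamide nitrogen in a ring. Among the measured compounds shown here, no measured step covers this exchange of 4-cyanophenyl for 3-cyanophenyl, and the two steps into compound 3 give no readable size. The author therefore expects no step beyond the scatter in this assay, so that the step of an at least 1.0-fold lower number from compound 3 to compound 4 (0.00 log units; that floor lies within the scatter) is estimated to be small. Compound 4 is expected to give about 300000 nM, within 150000 nM to 600000 nM, most likely again as a limit.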

Compound 4, half-maximal cytotoxic concentration: 8500 nM
Compound 4: the middle estimate sits 35-fold (1.55 log units) above what was measured; measured number outside the range, below it.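

In this assay, the change from 3-cyanobenzyl to 4-cyanobenzyl, with the same atoms joined differently, gives an at least 35-fold lower number from compound 3 to compound 4 (1.55 log units; beyond the scatter), so the place on a saturated chain carbon bound to a sulfonamide nitrogen in a ring proves sensitive to where the nitrile sits, which the earlier unreadable steps could not show. Among the compounds shown here, the same group gives an at least 35-fold lower number from compound 2 to compound 4 (1.54 log units; beyond the scatter), and in place of hydrogen it gives a 44-fold lower number from compound 1 to compound 4 (1.64 log units; beyond the scatter), the first step of readable size at this nitrogen. The step from compound 3 is only a floor, because compound 3 stands at a limit of the assay: the limit of > 305000 nM in this assay, at which 1 of the 4 values shown sits.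

The compounds shown leave open why the shift of the nitrile has so large an effect. They also leave open how a carboxylic acid or an amine would read in place of the nitrile on the 4-cyanobenzyl group.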